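This account rests on a few compounds, and the source may have more. Where it says the series, first, only, none or still open, it means among the compounds named here.

In a functional assay on LM7 cells (Homo sapiens) for cytotoxicity, read by MTT assay, with a stated time of 72 h (on this read-out higher numbers stand for weaker inhibition and lower numbers for stronger inhibition), compound 3 `Nc1nc(SCc2coc3ccccc3c2=O)n[nH]1` gives 16900 nM. Compound 1 `O=c1cc(CSc2nc3ccccc3o2)c2ccc(O)c(O)c2o1` reaches only the limit of the assay, > 25000 nM. Compound 2 `Cc1cc(C)n2nc(SCc3nnc(SCc4cc(=O)c5ccccc5o4)s3)nc2n1` likewise stops at the limit, > 25000 nM. Within the data shown here, compound 3 therefore stands as the one compound with a measured number in this assay, while two of the three values shown sit at the limit of > 25000 nM in this assay, at which 2 of the 3 values shown sit. Compound 4 `Nc1nnc(SCc2coc3ccccc3c2=O)s1` differs from compound 3 by 5-amino-1,3,4-thiadiazol-2-yl in place of 5-amino-1H-1,2,4-triazol-3-yl on a sulfur. Among the measured compounds shown here, no measured pair shows this kind of exchange, so the step is expected to be small, within the usual scatter, and is estimated as a 1.1-fold lower number from compound 3 to compound 4 (0.05 log units; within the scatter). Compound 4 is thus expected to give about 15000 nM in this assay, between 6000 nM and 40000 nM.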

Compound 4, half-maximal inhibitory concentration: 730 nM
Compound 4: middle estimate off by 21-fold (1.31 log units), on the high side; the whole stated range lies above it.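

In this assay, the group on this sulfur proves decisive: 5-amino-1,3,4-thiadiazol-2-yl in place of 5-amino-1H-1,2,4-triazol-3-yl gives a 23-fold lower number from compound 3 to compound 4 (1.36 log units; beyond the scatter). Both groups are five-membered aromatic rings with equal heavy atom counts and no net charge, so an exchange within one ring size is enough for a step of this size. The other compounds offer no second number to set against it: the limit of > 25000 nM in this assay, at which 2 of the 4 values shown sit.

Which difference between the two rings carries the step stays open. So does whether a methyl group in place of the amine, or a longer chain on the sulfur, would keep the lower number.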